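Exchanging a fluorine for a nitrile on the pyridine ring

The source may report more compounds than this note shows. Statements on the series, on what has been measured and on what is new or still open speak of the compounds shown alone.

Compound 1 `COc1cccc(Nc2cc3[nH]c(-c4cccc(C(F)(F)F)c4)nc3cn2)n1` and compound 2 `Fc1ccc(Nc2cc3[nH]c(-c4cccc(C(F)(F)F)c4)nc3cn2)nc1` share one core and differ only in the ring carried on the amine nitrogen. In a physicochemical assay for solubility, using the shake flask method, measured as kinetic solubility, with a stated time of 20 h, at pH 2 (on this read-out higher numbers stand for higher solubility and lower numbers for lower solubility), compound 1 gives 85000 nM. Compound 2 reaches only (the limit of < 5000 nM in this assay, at which 1 of the 2 values shown sits), so in this assay compound 2 shows < 5000 nM, which is a boundary of the measurement rather than a number. Going by the values given here, the single measured step is an at least 17-fold lower number from compound 1 to compound 2 (1.23 log units; beyond the scatter), a large drop. Compound 3 `N#Cc1ccc(Nc2cc3[nH]c(-c4cccc(C(F)(F)F)c4)nc3cn2)nc1` differs from compound 2 by cyano in place of fluoro on an aromatic carbon. Because compound 2 already sits at the limit of < 5000 nM in this assay, at which 1 of the 2 values shown sits, the change in compound 3 is expected to give a step that the limit leaves unreadable from compound 2 to compound 3, no step beyond the scatter, and the assay may again report only a limit. Compound 3 is therefore estimated at 3000 nM, with a likely range from 800 nM to 10000 nM.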

Compound 3, solubility: < 5000 nM
Compound 3 was reported as a limit; the forecaster's own chance of this, stated with the estimate: 65%; the middle value is on the limit's open side.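

In this assay compound 3 gives < 5000 nM, which is a limit and not a number. Cyano on this aromatic carbon, two atoms from the ring nitrogen, thus ends at the same limit as fluoro, so a second group at this position gives no readable number, and the change from 6-methoxypyridin-2-yl to 5-cyanopyridin-2-yl gives an at least 17-fold lower number from compound 1 to compound 3 (1.23 log units; beyond the scatter). The step between compound 2 and compound 3 cannot be read, because both values are limits: the limit of < 5000 nM in this assay, at which 2 of the 3 values shown sit.

As far as these compounds go, how far under that limit compound 2 and compound 3 really lie, and whether they differ at all, stays open. So does whether an amine or a carboxylic acid on the same aromatic carbon would give a readable number in this assay.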